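The compounds below may be only part of what the source reports. "The series", "measured", "known", "first", "only" and "open" are said of these compounds alone.

This account follows the step from compound 1 `O=C(CCCCCCCCc1ccccc1)N1CCCCC1` to compound 4 `O=C(CCCCCCCCc1ccc(Cl)cc1)N1CCCCC1`. In a functional assay on PANC-1 cells (Homo sapiens) for cytotoxicity, read by WST assay, with a stated time of 24 h (on this read-out lower numbers stand for stronger inhibition and higher numbers for weaker inhibition), compound 1 gives > 100000 nM, and this is a limit of the assay, not a number. Compound 2 `S=C(CCCCCCCCc1ccccc1)N1CCCCC1` also reaches only the limit, giving > 100000 nM in this assay. Compound 3 `O=C(CCCOCCCCc1ccccc1)N1CCCCC1` stands the same way, with > 100000 nM in this assay as a further limit. Compound 1 therefore stands where every value shown stands: at the limit of > 100000 nM in this assay, at which 3 of the 3 values shown sit, so no number among the three allows ranking, and nothing is known of any step between them.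

Compound 4 differs from compound 1 by chloro in place of hydrogen on an aromatic carbon, which, read one bond further out, turns phenyl into 4-chlorophenyl. With all three measured compounds at the limit, the step expected in this assay is none beyond the scatter, so the step from compound 1 to compound 4 is expected to be a number no higher from compound 1 to compound 4 (the limit leaves the size open). Compound 4 is accordingly estimated at 100000 nM, with a range from 30000 nM to 300000 nM, and most likely to return only a limit again.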

Compound 4, half-maximal inhibitory concentration: 65500 nM
For compound 4 the middle estimate is 1.5-fold (0.18 log units) above the measured one; the range from low to high includes it.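

In this assay compound 4 is the first compound shown to give a number and not a limit, so chloro in place of hydrogen on an aromatic carbon, para to a large group, is the one change here that is followed by a reading within the range of the assay. As far as these compounds go, the step is an at least 1.5-fold lower number from compound 1 to compound 4 (0.18 log units; that floor lies within the scatter); compound 1 stands at a limit, so this is only a floor, and the true size of the step stays open. Steps among the other compounds cannot be read, as their values remain limits: the limit of > 100000 nM in this assay, at which 3 of the 4 values shown sit.

Whether this reading is particular to chloro stays open, since fluoro, bromo, methyl and methoxy on the same carbon are not among the compounds shown. Also open, from the compounds shown here alone, is how the chain and the amide end would respond with chloro present, for instance with a longer chain, an amine or a carboxylic acid.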